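The compounds below may be only part of what the source reports. "The series", "measured", "known", "first", "only" and "open" are said of these compounds alone.

Working notes on the series. Compound 1 `CSc1cc(N)nc2[nH]cnc12` carries a methylsulfanyl group and no sugar; in a functional assay on KB cells (Homo sapiens) for cytotoxicity (a higher number here means that more compound is needed for the effect, a lower number that less compound is needed), compound 1 gives only a limit, > 22 ug/mL. Compound 2 `CSc1cc(N)nc2c1ncn2[C@@H]1O[C@H](CO)[C@@H](O)[C@H]1O` adds the sugar; in this assay compound 2 likewise gives only a limit, > 22 ug/mL. Compound 3 `Nc1cc(S)c2ncn([C@@H]3O[C@H](CO)[C@@H](O)[C@H]3O)c2n1` has hydrogen in place of methyl on the sulfur; in this assay compound 3 again gives only a limit, > 22 ug/mL. The step that the two limits leave unreadable from compound 2 to compound 3 is therefore not readable, both ends being limits. On where compound 3 stands: the limit of > 22 ug/mL in this assay, at which 3 of the 3 values shown sit, so compound 3 sits at the same limit as the other two measured compounds, with no number under it and no ordering possible among the three.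

The next compound, compound 4 `Nc1cc(Cl)c2ncn([C@@H]3O[C@H](CO)[C@@H](O)[C@H]3O)c2n1`, differs from compound 3 by chloro in place of sulfanyl on an aromatic carbon. Among the compounds with values here, no measured step bears on this exchange; the only measured step, a step that the two limits leave unreadable from compound 2 to compound 3, concerns the same carbon but is itself unreadable. Within the data shown here, no direction or size can be taken from the measured compounds, and the series so far gives no number at all to anchor on. Compound 4 is therefore expected to give 30 ug/mL in this assay, with a range of 8 ug/mL to 100 ug/mL, most likely reported again as a limit rather than a number. The step that the limit leaves unreadable from compound 3 to compound 4 is accordingly expected to be small, with no reliable direction.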

Compound 4, concentration for half-maximal effect: > 22 ug/mL
Compound 4: a limit, no number; the forecaster's own chance of this, stated with the estimate: 65%; the middle value does not contradict the limit.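

In this assay compound 4 again gives only a limit and no number, so the steps from compound 2 and from compound 3 to compound 4 cannot be read: the limit of > 22 ug/mL in this assay, at which 4 of the 4 values shown sit.

On these data alone, whether the sugar or the exchange among methylsulfanyl, sulfanyl and chloro changes the concentration needed stays open; compound 1, compound 2, compound 3 and compound 4 offer no number to compare.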